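Methyl to ethyl on the piperazine of compound 3

The source may hold more compounds than are shown below. What is called first, only, known or untested is meant among the compounds shown, and "the series" means these compounds.

Three compounds share a core and differ only at the edges. Compound 1 `CC(C)n1c(=O)n(C(=O)NCCN2CCN(C)CC2)c2cc(F)ccc21` gives 108 nM in an assay on isolated protein (striatum) for binding affinity to 5-hydroxytryptamine receptor 4 (Cavia porcellus), read by radioligand binding; a higher number here means a weaker inhibitor, a lower number a stronger inhibitor; compound 2 `CCn1c(=O)n(C(=O)NCCN2CCN(C)CC2)c2ccccc21` gives 75.4 nM; compound 3 `CC(C)n1c(=O)n(C(=O)NCCN2CCN(C)CC2)c2ccccc21` gives 91.1 nM. Compound 3 stands second highest of the three numbers, but the whole spread is small: the step of a 1.2-fold lower number from compound 1 to compound 3 (0.07 log units; within the scatter) and the step of a 1.2-fold higher number from compound 2 to compound 3 (0.08 log units; within the scatter) both lie within the scatter, so the three values cannot be ordered with confidence.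

Compound 4 `CCN1CCN(CCNC(=O)n2c(=O)n(C(C)C)c3ccccc32)CC1` differs from compound 3 by methyl in place of hydrogen on a saturated chain carbon bound to an amine nitrogen in a ring. Among the compounds with values here, neither measured step touches the same place, so there is no direct precedent for this change; what the two steps do show is that a change of one carbon elsewhere on the edge of the core, and a change of fluoro to hydrogen, each left this assay essentially unmoved. On that basis a further single-carbon addition is expected to produce no step beyond the scatter, and a 1.1-fold higher number from compound 3 to compound 4 (0.04 log units; within the scatter) is the estimated result. Compound 4 is therefore expected to give about 100 nM, with a plausible range from 40 nM to 250 nM.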

Compound 4, inhibition constant: 104 nM
Beside the measured number, compound 4's estimate is 1.0-fold (0.02 log units) below it; the measured number falls inside the stated range.
By their numbers in this assay, from the lowest: compounds 2, 3, 4 and 1 (each within the scatter of the next).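

In this assay, within the data shown here, the step from 4-methylpiperazin-1-yl to 4-ethylpiperazin-1-yl gives a 1.1-fold higher number from compound 3 to compound 4 (0.06 log units; within the scatter) and is the first direct reading at this position, so compound 3 and compound 4 cannot be told apart here. The earlier steps shown here covered only the fluoro on an aromatic carbon and the saturated chain carbon bound to an aromatic nitrogen and a saturated chain carbon, so they said nothing about this place. Now a third place on the shared core, a saturated chain carbon bound to an amine nitrogen in a ring, also takes a methyl in place of a hydrogen with a step that stays within the scatter, and nothing at hand offers an explanation for this result.

With only methyl and ethyl at this ring nitrogen, a single small step cannot show how far this insensitivity reaches. A longer chain such as butyl, a benzyl group, or a plain hydrogen on that nitrogen could still move the number beyond the scatter, and the compounds shown leave that open.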